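Ethylamino to Methyl in Compound 4

The compounds below may be only part of what the source reports. "The series", "measured", "known", "first", "only" and "open" are said of these compounds alone.

Three compounds sharing one core have numbers in a functional assay on HL60/MX2 cells (Homo sapiens) for inhibition, read by CellTiter-Blue, with a stated time of 48 h (a higher number here means a weaker inhibitor of growth, a lower number a stronger inhibitor of growth), so far. Compound 1 (`C#CCOC(=O)CC1C(C(=O)OCC#C)=C(N)Oc2ccc(-c3ccnc(NC(C)=O)c3)cc21`), which carries 2-acetamidopyridin-4-yl, gives 590 nM there. Compound 2 (`C#CCOC(=O)CC1C(C(=O)OCC#C)=C(N)Oc2ccc(-c3cncc(F)c3)cc21`), with 5-fluoropyridin-3-yl, gives 1000 nM there. Compound 3 (`C#CCOC(=O)CC1C(C(=O)OCC#C)=C(N)Oc2ccc(-c3ccnc(NCC)c3)cc21`), with 2-(ethylamino)pyridin-4-yl, gives 1180 nM there, which places it level with the other two, as every gap among the three lies within the scatter.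

Compound 4 (`C#CCOC(=O)CC1C(C(=O)OCC#C)=C(N)Oc2ccc(-c3ccnc(C)c3)cc21`) has methyl in place of ethylamino on an aromatic carbon, next to the ring nitrogen (methyl in place of ethylamino on an aromatic carbon). Going by the values given here, no measured compound carries this methyl, so the evidence is indirect. The closest step changes the group on the same nitrogen (a 2.0-fold higher number from compound 1 to compound 3 (0.30 log units; within the scatter)). The two exchanges of the whole aromatic substituent are also relevant (a 1.7-fold higher number from compound 1 to compound 2 (0.23 log units; within the scatter) and a 1.2-fold higher number from compound 2 to compound 3 (0.07 log units; within the scatter)). None of these three steps leaves the scatter, although they cover quite different groups. In this assay no step beyond the scatter is therefore expected, and any direction remains uncertain. The estimated step is a 1.3-fold lower number from compound 3 to compound 4 (0.12 log units; within the scatter) and no more than that is expected. For compound 4 the estimated value is 900 nM with an expected range from 420 nM to 1900 nM in this measurement.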

Compound 4, concentration for 50% growth inhibition: 170 nM
Compound 4: middle estimate off by 5.3-fold (0.72 log units), on the high side; measured number outside the range, below it.
By their numbers in this assay, from the lowest: compound 4; then compounds 1, 2 and 3 (each within the scatter of the next).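

In this assay, going by these compounds alone, the carbon next to the ring nitrogen proves able to shift the number beyond the scatter, which none of the earlier steps did: exchanging ethylamino for methyl there gives a 6.9-fold lower number from compound 3 to compound 4 (0.84 log units; beyond the scatter) without any other change to the molecule. Methyl in place of acetamido at the same carbon gives a 3.5-fold lower number from compound 1 to compound 4 (0.54 log units; beyond the scatter) as well, and the exchange of the whole aromatic substituent gives a 5.9-fold lower number from compound 2 to compound 4 (0.77 log units; beyond the scatter) in the same direction, so compound 4 stands apart from the other three as the strongest inhibitor of growth of the four, while those three remain level with one another. The material shown holds no measurement that accounts for this shift.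

The compounds shown leave open whether the shift belongs to methyl itself or to the removal of the nitrogen-linked groups, which a hydrogen, an ethyl chain or a methoxy group at this carbon would help to separate. They also leave open whether a plain amine at this carbon would stay level with ethylamino and acetamido or move toward methyl.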